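This account rests on a few compounds, and the source may have more. Where it says the series, first, only, none or still open, it means among the compounds named here.

Compound 1 `COc1ccc(-c2cnc(NC(=O)c3ncc[nH]3)n2C)cc1` and compound 2 `COc1ccc(-c2cnc(NC(=O)c3ccc(O)cc3)n2C)cc1` share one core and differ only at the group on the carbonyl carbon. In a toxicity assay on THP-1 cells (Homo sapiens) for inhibition (a higher number here means that more compound is tolerated, a lower number that less compound is tolerated), compound 1 gives no number but a limit of the assay, > 100000 nM. Compound 2 likewise gives only a limit in this assay, > 100000 nM. Among the measured compounds shown here, the step that the two limits leave unreadable from compound 1 to compound 2 is therefore not readable in size, and the sole thing both values show is the limit of > 100000 nM in this assay, at which 2 of the 2 values shown sit. Compound 3 `COc1ccc(-c2cnc(NC(=O)c3ccccc3)n2C)cc1` differs from compound 2 by hydrogen in place of hydroxy on an aromatic carbon. For the measured compounds named here, no measured step resolves a change of this kind; the one step recorded is unreadable, and both values sit at the same limit. Compound 3 is therefore expected to sit near 150000 nM, with a range from 50000 nM to 500000 nM, most likely reported again as a limit. The expected step that the limit leaves unreadable from compound 2 to compound 3 would not go beyond the scatter.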

Compound 3, half-maximal cytotoxic concentration: > 100000 nM
Compound 3: only a limit was reported; the forecaster's own chance of this, stated with the estimate: 75%; the middle value is on the limit's open side.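

Compound 3, like compound 1 and compound 2, gives only a limit in this assay, so no step among these compounds can be read in size: the limit of > 100000 nM in this assay, at which 3 of the 3 values shown sit.

What the compounds shown leave open is whether any group on the carbonyl carbon changes how much compound these cells tolerate.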